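This account rests on a few compounds, and the source may have more. Where it says the series, first, only, none or still open, it means among the compounds named here.

Working notes on the series. a functional assay on ZR-75-1 cells (Homo sapiens) for cytotoxicity, read by MTT assay, with a stated time of 72 h (on this read-out lower numbers stand for an effect already at smaller amounts and higher numbers for an effect only at larger amounts of compound), is the only read-out here. Compound 1 `CCc1cccc2c(OC)c(-c3occ(C)c3C(=O)OC)ccc12` gives 1.3 ug/mL in this assay. Compound 2 `CCc1cccc2c(OC(C)=O)c(-c3occ(C)c3COC(C)=O)ccc12` reaches only a limit of this assay, > 10 ug/mL, and no number is available for it. Among the measured compounds shown here, compound 3 `CCOCc1c(C)coc1-c1ccc2c(CC)cccc2c1OC` gives 9.1 ug/mL in this assay, the higher of the two numbers recorded; its nearest neighbour is compound 1, and the single measured step, a 7.0-fold higher number from compound 1 to compound 3 (0.85 log units; beyond the scatter), is the only one-place comparison available. That step replaces the methoxycarbonyl group and does not touch the oxygen that changes next.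

Compound 4 `CCc1cccc2c(OC)c(-c3occ(C)c3COC(C)=O)ccc12` differs from compound 3 by acetyl in place of ethyl on an oxygen on a saturated carbon. For the measured compounds named here, no measured step bears directly on this exchange. The one point of reference is the limit of > 10 ug/mL in this assay, at which 1 of the 3 values shown sits, the value of compound 2, which carries the acetoxymethyl group of compound 4 alongside a second acetyl exchange. Compound 3 already sits close to that limit. The step of a 1.1-fold higher number from compound 3 to compound 4 (0.04 log units; within the scatter) is therefore expected to stay within the scatter, or to rise slightly, with a real chance that this assay reports only a limit. Compound 4 is estimated at 10 ug/mL in this assay, within a range of 4 ug/mL to 25 ug/mL.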

Compound 4, concentration for half-maximal effect: 3.5 ug/mL
Compound 4: the middle estimate sits 2.9-fold (0.46 log units) above what was measured, outside the stated range (below it).
By their numbers in this assay, from the lowest: compound 1; then compound 4; then compound 3. At a limit, above all of these: compound 2.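

Among the compounds shown here, the exchange of ethoxy to acetoxy is the first measured change on this oxygen on a saturated carbon, and a 2.6-fold lower number from compound 3 to compound 4 (0.41 log units; beyond the scatter) shows that the acetyl group moves the number down, not toward the limit. On the aromatic carbon, acetoxymethyl does not recover the number of the methoxycarbonyl group, a 2.7-fold higher number from compound 1 to compound 4 (0.43 log units; beyond the scatter), but that step is smaller than a 7.0-fold higher number from compound 1 to compound 3 (0.85 log units; beyond the scatter), so the three groups now rank methoxycarbonyl, acetoxymethyl, ethoxymethyl from the lowest number up. Compound 2 gives only a limit, so its comparison reads as a bound, an at least 2.8-fold lower number from compound 2 to compound 4 (0.45 log units; beyond the scatter), and it ties that limit to the acetyl on the oxygen on an aromatic ring, not to the acetoxymethyl group shared with compound 4: the limit of > 10 ug/mL in this assay, at which 1 of the 4 values shown sits.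

Open, as far as these compounds go, is how a hydroxymethyl or an aminomethyl group would read on this aromatic carbon, and whether a longer chain than ethyl on the oxygen on a saturated carbon would keep the number of compound 3 or shift it. The ethyl group on the shared core is the same in all four compounds, so what it contributes cannot be read.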